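Piperazinylmethyl aminothiophene series: aryl swap on the ring nitrogen

The source may report more compounds than this note shows. Statements on the series, on what has been measured and on what is new or still open speak of the compounds shown alone.

Measured compounds:
compound 1 `Nc1scc(CN2CCN(c3cccc(C(F)(F)F)c3)CC2)c1C(=O)c1ccc(Cl)cc1`, -30%
compound 2 `Nc1scc(CN2CCN(c3ccc(Cl)c(C(F)(F)F)c3)CC2)c1C(=O)c1ccc(Cl)cc1`, -12%
compound 3 `Nc1scc(CN2CCN(c3cccc(F)c3)CC2)c1C(=O)c1cccc(C(F)(F)F)c1`, -12%

In a functional assay on CHO cells with adenosine receptor A1 (Homo sapiens) as the target, read by cAMP accumulation and immunoassay, with a stated time of 6 min, tested at 0.1 uM (a higher number here means a weaker effect of the compound at the concentration tested, a lower number a stronger effect), compound 1 gives the lowest of the three numbers; compound 2 and compound 3 both sit higher by the same margin, beyond the scatter. Within the data shown here, the one single-point step measured, a number 18 percentage points higher from compound 1 to compound 2 (beyond the scatter), was modest. Compound 4 `Nc1scc(CN2CCN(c3cc(F)cc(F)c3)CC2)c1C(=O)c1ccc(Cl)cc1` differs from compound 1 in one place: 3,5-difluorophenyl in place of 3-(trifluoromethyl)phenyl on an amine nitrogen in a ring. Among the measured compounds shown here, no measured step bears directly on this exchange; compound 3 carries a fluorophenyl but also a different benzoyl, so only its value is known. For the measured compounds named here, the expectation is a modest rise, a number 15 percentage points higher from compound 1 to compound 4 (beyond the scatter), by analogy with the only step available. Compound 4 is therefore expected to give -15%, between -35% and 5%.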

Compound 4, a percentage reported as activity, at one concentration (the size of the read-out at that concentration, not a potency): -5%
For compound 4 the middle estimate is 10 percentage points below the measured one; the range from low to high includes it.
By their numbers in this assay, from the lowest: compound 1; then compounds 2, 3 and 4 (each within the scatter of the next).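

In this assay, 3,5-difluorophenyl in place of 3-(trifluoromethyl)phenyl on the ring nitrogen gives a number 25 percentage points higher from compound 1 to compound 4 (beyond the scatter), so this position responds to an aryl exchange while the rest of compound 1 stays unchanged. Set against the 4-chloro-3-(trifluoromethyl)phenyl group, the same 3,5-difluorophenyl group gives a number 7 percentage points higher from compound 2 to compound 4 (within the scatter), so these two aryl groups are not separated here. No available evidence accounts for either step.

Open, on these data alone, is how an unsubstituted phenyl, a methoxyphenyl or a pyridyl group on this nitrogen would read in this assay.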